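This account rests on a few compounds, and the source may have more. Where it says the series, first, only, none or still open, it means among the compounds named here.

In a functional assay on HCT-116 cells (Homo sapiens) for cytotoxicity, read by sulforhodamine B assay, with a stated time of 24 h (on this read-out lower numbers stand for stronger inhibition and higher numbers for weaker inhibition), two compounds sharing the same core have been measured so far. Compound 1 `O=C1Nc2ccc(S(=O)(=O)N3CCOCC3)cc2/C1=N/c1ccc(Br)cc1` gives 15300 nM, and compound 2 `O=C1Nc2ccc(S(=O)(=O)N3CCOCC3)cc2/C1=N/c1ccc(C(=O)O)cc1` gives 23600 nM. These two numbers cannot be told apart, as the measured step is a 1.5-fold higher number from compound 1 to compound 2 (0.19 log units; within the scatter). Compound 2 therefore stands level with compound 1 on the numbers available.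

Compound 3 `O=C1Nc2ccc(S(=O)(=O)N3CCOCC3)cc2/C1=N/NS(=O)(=O)c1ccccc1` keeps the core but carries (phenylsulfonyl)amino in place of 4-carboxyphenyl on a double-bonded nitrogen. For the measured compounds named here, only one measured step bears on this change, and it is an indirect guide. It placed carboxy in place of bromo on an aromatic carbon, whereas the new change removes the whole 4-carboxyphenyl. With that single step being a 1.5-fold higher number from compound 1 to compound 2 (0.19 log units; within the scatter), no step beyond the scatter is expected in this assay, and neither direction is favoured. Going by the values given here, no measured pair changes the group on the double-bonded nitrogen as a whole, so the range must stay wide. The estimated step is a 1.2-fold lower number from compound 2 to compound 3 (0.07 log units; within the scatter). For compound 3 the expected value is 20000 nM, with an estimated range from 6000 nM to 60000 nM.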

Compound 3, half-maximal inhibitory concentration: 13300 nM
The estimate for compound 3 lay 1.5-fold (0.18 log units) above the measured number; low and high end bracket the measured number.
By their numbers in this assay, from the lowest: compounds 3, 1 and 2 (each within the scatter of the next).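

For the compounds shown here, compound 3 is the first compound here in which the whole group on the double-bonded nitrogen is exchanged, rather than only the substituent on its aromatic ring. In this assay that larger exchange gives a 1.8-fold lower number from compound 2 to compound 3 (0.25 log units; within the scatter) and a 1.2-fold lower number from compound 1 to compound 3 (0.06 log units; within the scatter) so neither step separates (phenylsulfonyl)amino from the aryl groups it replaces. Across these three compounds, even a change that brings a sulfur and an extra nitrogen into this place leaves the numbers within the scatter of one another, and no measurement given here offers an explanation for that.

Going by these compounds, what remains open is whether any group on this nitrogen can move the number beyond the scatter in either direction, for example a simple amine, a longer alkyl chain or a phenyl ring carrying a methoxy group. All three compounds also share the same core, so these results say nothing about how the number would respond to a change elsewhere on it.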